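The source may hold more compounds than are shown below. What is called first, only, known or untested is meant among the compounds shown, and "the series" means these compounds.

Measured in a functional assay on A549 cells (Homo sapiens) for cytotoxicity, read by MTT assay, with a stated time of 6 days; a lower number here means that less compound is needed, a higher number that more compound is needed for the effect:
- compound 1 `Nc1ccc(-c2cc(=O)c3cc(O)ccc3o2)cc1`: 2.72 ug/mL
- compound 2 `COc1cc(-c2cc(=O)c3cc(O)ccc3o2)cc(OC)c1OC`: 9.82 ug/mL

Compound 2, at 9.82 ug/mL, holds the higher of the two numbers, and its gap to compound 1 lies beyond the scatter. Compound 3 `COc1cc(-c2cc(=O)c3cc(O)ccc3o2)cc(OC)c1O[Si](C)(C)C(C)(C)C` is compound 2 with one change on an oxygen on an aromatic ring: a group of 7 heavy atoms (6 carbon, 1 silicon; no ring) in place of one carbon atom, on an oxygen on an aromatic ring. Among the compounds with values here, no measured pair shows this change, so the expectation is loose. The expected result in this assay is no shift beyond the scatter, with the estimate a little on the lower side: a 1.5-fold lower number from compound 2 to compound 3 (0.18 log units; within the scatter). Compound 3 is estimated at 6.5 ug/mL, with an expected range of 2.2 ug/mL to 20 ug/mL.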

Compound 3, concentration for half-maximal effect: 3.19 ug/mL
Beside the measured number, compound 3's estimate is 2.0-fold (0.31 log units) above it, within the range that was stated.
By their numbers in this assay, from the lowest: compounds 1 and 3 (each within the scatter of the next); then compound 2.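

The oxygen on the aromatic ring accepts a much larger group than methyl: in this assay, the group of 7 heavy atoms (6 carbon, 1 silicon; no ring) in place of one carbon atom gives a 3.1-fold lower number from compound 2 to compound 3 (0.49 log units; beyond the scatter), a modest step. Compound 1 and compound 2 alone could not show how this position responds to a change. No measurement at hand gives a reason for the step.

From the compounds shown here alone, whether the step follows the silicon or the size of the group stays open. A hydroxyl at this place, or an all-carbon chain such as butyl on this oxygen, could help separate the two.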